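A few compounds are considered here, and "the series" means these few. Any claim that something is new, unique, unknown or untested is made for them only; others in the source may bear on it.

Compound 1, `N#Cc1cccc(CN2C(=O)N(Cc3ccccc3)S(=O)(=O)n3cccc32)c1`: in an ADME assay on MT4 cells (Homo sapiens) for cytotoxicity, read by MTT assay, with a stated time of 5 days (a lower number here means that less compound is tolerated, a higher number that more compound is tolerated), compound 1 gives > 318000 nM, which is a limit of the assay rather than a number.
Compound 2, `O=C1N(Cc2cccc(Cl)c2)c2cccn2S(=O)(=O)N1Cc1cccc(F)c1`: in this assay compound 2 gives 208000 nM.
Compound 3, `O=C1N(Cc2ccccc2)c2cccn2S(=O)(=O)N1Cc1cccc(F)c1`: in this assay compound 3 gives > 288000 nM, again a limit and not a number.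

Compound 1 therefore stands only at a limit, and of the three values shown one further value is also a limit: the limit of > 318000 nM in this assay, at which 1 of the 3 values shown sits, and (the limit of > 288000 nM in this assay, at which 1 of the 3 values shown sits). For the measured compounds named here, the only measured step between two compounds that differ in one place is an at least 1.3-fold higher number from compound 2 to compound 3 (0.14 log units; that floor lies within the scatter), hydrogen in place of chloro on an aromatic carbon, and its floor lies within the scatter.

Compound 4, `O=C1N(C/C=C/c2ccccc2)c2cccn2S(=O)(=O)N1Cc1ccccc1`, differs from compound 1 by 2-phenylethenyl in place of 3-cyanophenyl on a saturated chain carbon bound to an amide-type nitrogen in a ring. The measured step touches a different position and a different kind of change, so it gives no direct guide to this one. Among the three measured compounds no step beyond the scatter appears, and the shared core is tolerated at high concentrations throughout. For this reason no step beyond the scatter is expected for compound 4 in this assay, and a limit is again a likely outcome. Compound 4 is estimated at 300000 nM, with a range from 100000 nM to 700000 nM. This estimate means an expected step of an at least 1.0-fold lower number from compound 1 to compound 4 (0.02 log units; that floor lies within the scatter).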

Compound 4, half-maximal cytotoxic concentration: > 318000 nM
Compound 4 was reported as a limit; the forecaster's own chance of this, stated with the estimate: 60%; at least 1.0-fold (0.02 log units) between middle value and limit.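

Compound 1 and compound 4 both stand at the same limit of the assay rather than at a number, so no step between them can be read: the limit of > 318000 nM in this assay, at which 2 of the 4 values shown sit.

The compounds shown leave open whether 2-phenylethenyl and 3-cyanophenyl differ at all in the half-maximal cytotoxic concentration they give, since neither compound has a true value.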